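The source may hold more compounds than are shown below. What is called first, only, known or untested is meant among the compounds shown, and "the series" means these compounds.

Three ureas have been measured in an ADME assay on the whole organism with Oryza sativa as the target, tested at 10 uM (a lower number here means a stronger effect, a higher number a weaker effect of the compound at the concentration tested), so far. For the measured compounds named here, compound 1, `Cc1ccc(NC(=O)N[C@@H](C)c2ccccc2)cc1`, is the first; in this assay compound 1 gives 100%. Compound 3, `CCc1ccc(NC(=O)N[C@@H](C)c2ccccc2)cc1`, carries one change against compound 1, (methyl in place of hydrogen on a saturated chain carbon bound to an aromatic carbon), and in this assay compound 3 gives 91%. The step that this change made is a number 9 percentage points lower from compound 1 to compound 3 (within the scatter). Compound 2, `CCc1ccccc1NC(=O)N[C@H](C)c1ccccc1`, stands apart from compound 1 by more than one place; the difference between the two cores is not broken down here. In this assay compound 2 gives 92%. Going by the values given here, no step is given between compound 2 and compound 3, and their two values lie close together.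

Compound 4, `CC(C)c1ccccc1NC(=O)N[C@H](C)c1ccccc1`, has not yet been measured. It differs from compound 2 by methyl in place of hydrogen on a saturated chain carbon bound to an aromatic carbon and a saturated chain carbon. Among the compounds with values here, this is the same kind of change as the one from compound 1 to compound 3, but not the same: in compound 3 the carbon that takes the methyl is bound to an aromatic carbon only, whereas in compound 4 it is bound to an aromatic carbon and a saturated chain carbon. The only reference point for a change of this kind is the earlier step, so the step from compound 2 to compound 4 is expected to be of about the same size, a number 6 percentage points lower from compound 2 to compound 4 (within the scatter), because a number 9 percentage points lower from compound 1 to compound 3 (within the scatter) stayed within the scatter. On that basis compound 4 is estimated to give 86% in this assay, with a likely range from 70% to 100%.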

Compound 4, a percentage reported as activity, at one concentration (the size of the read-out at that concentration, not a potency): 17%
Compound 4: the middle estimate sits 69 percentage points above what was measured, and the stated range ends above it.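

In this assay, the methyl that turns the ethyl of compound 2 into the isopropyl of compound 4 gives a number 75 percentage points lower from compound 2 to compound 4 (beyond the scatter), a large step. Set beside the earlier step, this shows that the size of the change does not carry over from one core to the other in this series: the same change on two cores in this assay, a number 9 percentage points lower (within the scatter) from compound 1 to compound 3 and a number 75 percentage points lower (beyond the scatter) from compound 2 to compound 4, 66 percentage points apart, beyond the scatter of two such steps The result does not show what sets the two steps apart, since the two pairs differ both in their cores and in the carbon that takes the methyl, which is bound to an aromatic carbon only in compound 3 but also to a saturated chain carbon in compound 4, and two pairs give no general rule for the series.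

The compounds shown leave open whether an isopropyl on the core of compound 1 would bring a step as large as the one on the core of compound 2, which would separate the effect of the core from that of the group. They also leave open whether the large step belongs to isopropyl alone or extends to other groups in that place, such as a tert-butyl, a cyclopropyl or a longer propyl chain.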